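A Methyl Added to Compound 3: Expected Cell Toxicity

The compounds below may be only part of what the source reports. "The series", "measured", "known", "first", "only" and "open" are said of these compounds alone.

In an ADME assay on HepG2 cells (Homo sapiens) for cytotoxicity, read by resazurin assay, with a stated time of 24 h (on this read-out higher numbers stand for lower toxicity in this test and lower numbers for higher toxicity in this test), compound 3 `COc1cccc(C=Cc2ccc3ccccc3c2)c1C(=O)O` reaches only the limit of the test, > 100000 nM. Compound 1 `COc1cc(C=Cc2ccc3ccccc3c2)c(C(=O)O)c(OC)c1` likewise stops at a limit, giving > 100000 nM in this assay. Compound 2 `Cc1cc(O)c(C(=O)O)c(C=Cc2ccc3ccccc3c2)c1` yields an actual number, 30000 nM. Among the measured compounds shown here, the one measured step, a step that the two limits leave unreadable from compound 1 to compound 3, cannot be read because of the limit of > 100000 nM in this assay, at which 2 of the 3 values shown sit. Compound 4 `COc1cc(C)cc(C=Cc2ccc3ccccc3c2)c1C(=O)O` differs from compound 3 by methyl in place of hydrogen on an aromatic carbon. No measured step tracks such a methyl, and the two limits with a single number give no reason to expect a shift beyond the scatter. Compound 4 is therefore expected near 100000 nM, within 40000 nM to 300000 nM, most likely again reported only as a limit. The estimated step is then a number no higher from compound 3 to compound 4 (the limit leaves the size open), none beyond the scatter.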

Compound 4, half-maximal cytotoxic concentration: 117000 nM
The estimate for compound 4 lay 1.2-fold (0.07 log units) below the measured number; the measured number falls inside the stated range.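

In this assay, compound 4 gives a real number rather than a limit, so the methyl para to a carboxy group sits on a compound with a countable value. Among the compounds shown here, that number gives the first readable step to carry this methyl, a 3.9-fold higher number from compound 2 to compound 4 (0.59 log units; beyond the scatter), where methyl replaces the hydrogen on a ring oxygen and the higher number stands for lower toxicity in this test. The steps to compound 4 from compound 3 and from compound 1 cannot be read, set by a limit: the limit of > 100000 nM in this assay, at which 2 of the 4 values shown sit.

From the compounds shown here alone, what the methyl alone does therefore stays open. So does how an amine or a longer chain would read at this place.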